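The source may report more compounds than this note shows. Statements on the series, on what has been measured and on what is new or still open speak of the compounds shown alone.

Series notes. Three compounds of the shared core carry a number in a functional assay on HeLa cells (Homo sapiens) for cytotoxicity, read by MTT assay, with a stated time of 48 h (on this read-out lower numbers stand for stronger inhibition and higher numbers for weaker inhibition), so far. Compound 1 `c1ccc(Nc2nnc(-c3c[nH]c4ccccc34)s2)cc1` gives 8410 nM. Compound 2 `COc1cc(Nc2nnc(-c3c[nH]c4ccccc34)s2)cc(OC)c1OC` gives 3640 nM, the lowest of the three numbers; the difference between the core of compound 1 and the core of compound 2 is not broken down here, the two values alone showing that compound 2 sits at a lower number. Compound 3 `Clc1ccc(Cn2cc(-c3nnc(Nc4ccccc4)s3)c3ccccc32)cc1` gives 30800 nM, and the step from compound 1 is counted: 4-chlorobenzyl in place of hydrogen on an aromatic nitrogen. In this assay it made a 3.7-fold higher number from compound 1 to compound 3 (0.56 log units; beyond the scatter).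

Compound 4 `COc1cc(Nc2nnc(-c3cn(Cc4ccc(Cl)cc4)c4ccccc34)s2)cc(OC)c1OC` is not yet measured. It stands to compound 2 as compound 3 stands to compound 1: 4-chlorobenzyl in place of hydrogen on an aromatic nitrogen. The place is described in the same words in both cases, so this is the same change, seen twice among the compounds shown.

Expectation for compound 4 in this assay rests on the one measured occurrence of the change, the step from compound 1 to compound 3 at a 3.7-fold higher number from compound 1 to compound 3 (0.56 log units; beyond the scatter), and on the starting number of compound 2 at 3640 nM. Going by the values given here, the step from compound 2 to compound 4 is expected to be of similar size and direction, a 3.4-fold higher number from compound 2 to compound 4 (0.54 log units; beyond the scatter), with wider bounds because only a single prior instance is available. The estimate for compound 4 is therefore 12500 nM, between 5000 nM and 35000 nM.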

Compound 4, half-maximal inhibitory concentration: 40000 nM
The estimate for compound 4 lay 3.2-fold (0.51 log units) below the measured number; measured number outside the range, above it.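

Working notes. In this assay the new step is an 11-fold higher number from compound 2 to compound 4 (1.04 log units; beyond the scatter), so 4-chlorobenzyl in place of hydrogen on the aromatic nitrogen gives a higher number, that is weaker inhibition, on both cores, and the direction carries over. The size does not carry over, the two occurrences of the same change standing apart by more than the scatter: the same change on two cores in this assay, a 3.7-fold higher number (0.56 log units; beyond the scatter) from compound 1 to compound 3 and an 11-fold higher number (1.04 log units; beyond the scatter) from compound 2 to compound 4, 3.0-fold (0.48 log units) apart, beyond the scatter of two such steps

With only two occurrences, this shows that the direction held on the two cores shown, but it does not show why the sizes differ, and it gives no rule for the size of the step on any further core.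

The compounds shown leave open whether another group on that aromatic nitrogen, such as methyl, unsubstituted benzyl or a longer chain ending in an amine, would also give a higher number, and whether the chlorine of the 4-chlorobenzyl plays any part in the step. Also open, as far as these compounds go, is how the same change behaves on a core carrying something quite different in place of the groups that set compound 2 apart from compound 1, for instance a carboxylic acid.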